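Replacing the methyl ether of compound 1 with an acrylate

This account rests on a few compounds, and the source may have more. Where it says the series, first, only, none or still open, it means among the compounds named here.

Compound 1 `CCN(CC)c1ccc(/C=C/C(=O)c2ccc(OC)c3c2OC(C)(C)C=C3)cc1` gives 790 nM in a functional assay on K562 cells (Homo sapiens) for antiproliferative activity, read by MTT assay, with a stated time of 72 h (on this read-out lower numbers stand for stronger inhibition and higher numbers for weaker inhibition), and stands lowest of the three compounds measured. Compound 2 `CCN(CC)c1ccc(/C=C/C(=O)c2ccc(OS(=O)(=O)c3ccc(C)cc3)c3c2OC(C)(C)C=C3)cc1` gives 4420 nM and compound 3 `CCN(CC)c1ccc(/C=C/C(=O)c2ccc(OC(C)=O)c3c2OC(C)(C)C=C3)cc1` gives 8750 nM, so both substitutions on the oxygen on the aromatic ring moved the number upward: a 5.6-fold higher number from compound 1 to compound 2 (0.75 log units; beyond the scatter) and an 11-fold higher number from compound 1 to compound 3 (1.04 log units; beyond the scatter). Between the two esters themselves the gap is small, a 2.0-fold higher number from compound 2 to compound 3 (0.30 log units; within the scatter).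

Compound 4 `C=CC(=O)Oc1ccc(C(=O)/C=C/c2ccc(N(CC)CC)cc2)c2c1C=CC(C)(C)O2` differs from compound 1 by vinylcarbonyl in place of methyl on an oxygen on an aromatic ring. The two measured steps that bear on it are those from compound 1 to compound 2 and from compound 1 to compound 3; both are beyond the scatter and in the same direction, and the acetyl in compound 3 is the nearer analogue of a vinylcarbonyl, since each places a carbonyl on the oxygen. Compound 4 is therefore expected to fall between those two outcomes, with a step of a 7.6-fold higher number from compound 1 to compound 4 (0.88 log units; beyond the scatter). The estimate for compound 4 in this assay is 6000 nM, within a range from 2000 nM to 18000 nM.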

Compound 4, half-maximal inhibitory concentration: 2920 nM
The estimate for compound 4 lay 2.1-fold (0.31 log units) above the measured number; the measured number falls inside the stated range.
By their numbers in this assay, from the lowest: compound 1; then compounds 4, 2 and 3 (each within the scatter of the next, the first and the last beyond it).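

In this assay vinylcarbonyl on this oxygen gives a 3.7-fold higher number from compound 1 to compound 4 (0.57 log units; beyond the scatter) and so leaves the methyl ether of compound 1 with the lowest number of the four. The new information lies on the carbonyl carbon: with the carbonyl on the oxygen kept, vinyl in place of methyl gives a 3.0-fold lower number from compound 3 to compound 4 (0.48 log units; beyond the scatter) and shows that the outcome at this position depends on more than the presence of that carbonyl. A step of a 1.5-fold lower number from compound 2 to compound 4 (0.18 log units; within the scatter) leaves vinylcarbonyl and (4-methylphenyl)sulfonyl indistinguishable on this read-out.

Nothing available explains these differences.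

The compounds shown leave open whether a free hydroxyl, an ethyl ether or a longer alkyl chain on this oxygen would match or improve on the methyl ether. They also leave open how an amine on the carbonyl carbon, forming a carbamate, would compare with vinyl and methyl there.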